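Swapping an Ethyl for Bromo on the Pendant Ring

The compounds below may be only part of what the source reports. "The series", "measured", "known", "first", "only" and "open" are said of these compounds alone.

Compound 1, `COc1ccc2c(c1)CC/C(=C\c1ccccc1C(F)(F)F)C2=O`: 11200 nM
Compound 2, `COc1ccc2c(c1)CCC(Cc1ccccc1C(F)(F)F)C2=O`: 2080 nM
Compound 3, `CCc1ccccc1CC1CCc2cc(OC)ccc2C1=O`: 1920 nM

These three compounds were measured in an assay on CHO cells for inhibition of 1,25-dihydroxyvitamin D(3) 24-hydroxylase, mitochondrial (Homo sapiens); a lower number here means a stronger inhibitor, a higher number a weaker inhibitor. Compound 3 gives the lowest number of the three; its nearest neighbour is compound 2, whose value lies within the scatter of it, while compound 1 sits furthest away, beyond the scatter. Compound 4, `COc1ccc2c(c1)CCC(Cc1ccccc1Br)C2=O`, differs from compound 3 by bromo in place of ethyl on an aromatic carbon. Within the data shown here, one measured step bears on this change, since it also exchanges the group on that aromatic carbon: a 1.1-fold lower number from compound 2 to compound 3 (0.03 log units; within the scatter). That exchange left the number essentially unchanged. A step of similar size, or none beyond the scatter, is therefore expected for compound 4: a 1.0-fold higher number from compound 3 to compound 4 (0.02 log units; within the scatter). Compound 4 is estimated at 2000 nM, within a range from 800 nM to 5000 nM.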

Compound 4, half-maximal inhibitory concentration: 16300 nM
For compound 4 the middle estimate is 8.2-fold (0.91 log units) below the measured one; the whole stated range lies below it.
By their numbers in this assay, from the lowest: compounds 3 and 2 (each within the scatter of the next); then compounds 1 and 4 (each within the scatter of the next).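

This position is less forgiving than the earlier pair suggested: ethyl and trifluoromethyl gave numbers within the scatter of each other, but bromo weakens inhibition. The change shows up against both neighbours, with an 8.5-fold higher number from compound 3 to compound 4 (0.93 log units; beyond the scatter) and a 7.8-fold higher number from compound 2 to compound 4 (0.89 log units; beyond the scatter), so the group on this aromatic carbon can matter after all. Nothing measured here explains why bromo behaves differently. As far as these compounds go, it remains open whether this weakening is particular to bromo or extends to other halogens such as chloro. From the compounds shown here alone, how an amine or a carboxylic acid on this carbon would compare also remains unknown.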